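The source may hold more compounds than are shown below. What is called first, only, known or untested is meant among the compounds shown, and "the series" means these compounds.

Of the compounds shown here, three that share one core have been measured in a functional assay on MCF7 cells (Homo sapiens) for inhibition; on this read-out higher numbers stand for weaker inhibition and lower numbers for stronger inhibition. Compound 1 `CCOC(=O)c1ccc(NC(=O)N2CC2C#N)cc1` gives 2100 nM, compound 2 `N#CC1CN1C(=O)Nc1ccc([N+](=O)[O-])cc1` gives 3000 nM, and compound 3 `N#CC1CN1C(=O)Nc1ccc(C(F)(F)F)cc1` gives 1400 nM, the lowest of the three numbers, though its gap to compound 1 stays within the scatter. Exchanging the group on the aromatic ring shifted the numbers only modestly: a 1.4-fold higher number from compound 1 to compound 2 (0.15 log units; within the scatter), a 1.5-fold lower number from compound 1 to compound 3 (0.18 log units; within the scatter) and a 2.1-fold lower number from compound 2 to compound 3 (0.33 log units; beyond the scatter). Compound 4 `N#CC1CN1C(=O)Nc1ccc(S(N)(=O)=O)cc1` repeats this kind of exchange, with sulfamoyl in place of trifluoromethyl on an aromatic carbon. Because a 2.1-fold lower number from compound 2 to compound 3 (0.33 log units; beyond the scatter) was the largest of the three measured exchanges of this group and still modest, a comparably small step is expected in this assay, probably toward a somewhat higher number, estimated as a 1.8-fold higher number from compound 3 to compound 4 (0.25 log units; within the scatter). Compound 4 is therefore expected to give 2500 nM, within a range from 1000 nM to 6500 nM.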

Compound 4, half-maximal inhibitory concentration: > 15000 nM
Compound 4 was reported as a limit (the forecaster's own chance of this, stated with the estimate: 5%); middle value at least 6.0-fold (0.77 log units) away from the limit.
By their numbers in this assay, from the lowest: compounds 3, 1 and 2 (each within the scatter of the next, the first and the last beyond it). At a limit, above all of these: compound 4.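

In this assay, compound 4 is reported only as a limit, not as a number: the limit of > 15000 nM in this assay, at which 1 of the 4 values shown sits. The position is therefore not as forgiving as the earlier exchanges suggested, and the swap to sulfamoyl weakens inhibition clearly against all three earlier groups, with an at least 10-fold higher number from compound 3 to compound 4 (1.02 log units; beyond the scatter), an at least 5.0-fold higher number from compound 2 to compound 4 (0.69 log units; beyond the scatter) and an at least 7.1-fold higher number from compound 1 to compound 4 (0.85 log units; beyond the scatter). These steps are minimum sizes, so the true loss could be larger.

The compounds shown leave open whether the hydrogen-bond donor that enters with sulfamoyl matters. They also leave open how an amine or a carboxylic acid on this aromatic carbon would behave.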